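Swapping a pyridine for a triazole on a urea series

The source may report more compounds than this note shows. Statements on the series, on what has been measured and on what is new or still open speak of the compounds shown alone.

Compound 1 `Cc1cc(C)c(NC(=O)N(Cc2ccc(-c3cccnc3)cc2)C2CCCCCC2)c(C)c1` is a trisubstituted phenylurea whose nitrogen carries a cycloheptyl group and a benzyl arm bearing a pyridine. Among the measured compounds shown here, in an assay on microsomes from intestine for inhibition of acyl-CoA:cholesterol acyltransferase (Oryctolagus cuniculus) (on this read-out lower numbers stand for stronger inhibition and higher numbers for weaker inhibition), compound 1 gives 130 nM, the higher of the two numbers known, though compound 2 `Cc1cc(C)c(NC(=O)N(Cc2cccc(-c3cc[nH]n3)c2)C2CCCCCC2)c(C)c1`, at 65 nM, lies within the scatter of it. Compound 3 `Cc1cc(C)c(NC(=O)N(Cc2ccc(-n3nccn3)cc2)C2CCCCCC2)c(C)c1` differs from compound 1 by 2H-1,2,3-triazol-2-yl in place of pyridin-3-yl on an aromatic carbon. For the measured compounds named here, with no measured step of this kind to lean on, compound 3 is expected to stay within the scatter of compound 1, a step of a 1.5-fold higher number from compound 1 to compound 3 (0.19 log units; within the scatter). Compound 3 is estimated at 200 nM, between 60 nM and 700 nM.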

Compound 3, half-maximal inhibitory concentration: 130 nM
Beside the measured number, compound 3's estimate is 1.5-fold (0.19 log units) above it; the range from low to high includes it.
By their numbers in this assay, from the lowest: compounds 2, 1 and 3 (each within the scatter of the next).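

In this assay, 2H-1,2,3-triazol-2-yl in place of pyridin-3-yl gives no change at the digits printed from compound 1 to compound 3 (within the scatter), on an aromatic carbon para to a large group. At this place, then, a five-membered aromatic ring with 3 hetero atoms reads the same as a six-membered aromatic ring with 1 hetero atom. Nothing available explains why the two rings read alike. On these data alone, whether this place needs an aromatic ring at all stays open: a morpholine or a carboxylic acid on the same carbon would test that.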